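This account rests on a few compounds, and the source may have more. Where it says the series, first, only, none or still open, it means among the compounds named here.

Compound 1 `CCN(CC)c1cc2[nH]c(-c3ccc(C)cc3)nc2cc1NC(=O)C1CCC1`, compound 2 `CCOC(=O)Nc1cc(NC(=O)c2ccccc2OC)c2[nH]c(-c3ccc(Br)cc3)nc2c1` and compound 3 `CCOC(=O)Nc1cc(NC(=O)C2CCCCC2)c2[nH]c(-c3ccc(C(=O)OC)cc3)nc2c1` share a core and were tested in an ADME assay on Vero cells (Chlorocebus sabaeus) for cytotoxicity, with a stated time of 3 days; on this read-out higher numbers stand for weaker inhibition and lower numbers for stronger inhibition. In this assay compound 1 gives only a limit, > 200 ug/mL. Compound 2 likewise gives only a limit, > 200 ug/mL. Compound 3 also stands at a limit, > 200 ug/mL, so no measured number places it anywhere within the set. All three values sit at the same limit (the limit of > 200 ug/mL in this assay, at which 3 of the 3 values shown sit). Compound 4 `CCOC(=O)Nc1cc(NC(=O)c2ccc(OC)cc2)c2[nH]c(-c3ccc(C(=O)OC)cc3)nc2c1` has not yet been measured; it differs from compound 3 by 4-methoxyphenyl in place of cyclohexyl on a carbonyl carbon. With every measured value at this limit, the expected step in this assay, a number no higher from compound 3 to compound 4 (the limit leaves the size open), is none beyond the usual scatter. Compound 4 is therefore expected to give 200 ug/mL in this assay, within a range of 100 ug/mL to 400 ug/mL.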

Compound 4, half-maximal inhibitory concentration: > 200 ug/mL
Compound 4 gave a limit, no number; the forecaster's own chance of this, stated with the estimate: 85%; the middle value lies on the limit itself.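

Compound 3 and compound 4 both give only a limit, so no step can be read from one to the other: the limit of > 200 ug/mL in this assay, at which 4 of the 4 values shown sit. The compounds shown leave open at what concentration any of them would inhibit in this assay.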